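A few compounds are considered here, and "the series" means these few. Any claim that something is new, unique, unknown or untested is made for them only; others in the source may bear on it.

Compound 1, `COc1ccc(F)cc1CNCCCNc1ccnc2cc(Cc3ccc(C#N)cc3)ccc12`, is the reference point of this account. In an ADME assay on HepG2 cells (Homo sapiens) for cytotoxicity, read by luminescence, CellTiter-Glo and ATP content, with a stated time of 72 h (on this read-out lower numbers stand for an effect already at smaller amounts and higher numbers for an effect only at larger amounts of compound), compound 1 gives 6050 nM, the lowest of the two numbers available. For the measured compounds named here, compound 2, `c1ccc(Oc2ccc3c(NCCCNCc4ccco4)ccnc3c2)cc1`, is the only other measured compound, and in this assay compound 2 gives 15200 nM, a number beyond the usual scatter above that of compound 1. Compound 3, `COc1ccc(F)cc1CNCCCNc1ccnc2cc(Cc3cccc(C(F)(F)F)c3)ccc12`, has not yet been measured. It differs from compound 1 in one place: 3-(trifluoromethyl)phenyl in place of 4-cyanophenyl on a saturated chain carbon bound to an aromatic carbon. Going by the values given here, no measured pair showing this exchange of a 4-cyanophenyl for a 3-(trifluoromethyl)phenyl is available, so the size of the step rests on expectation alone. The step of a 1.3-fold lower number from compound 1 to compound 3 (0.13 log units; within the scatter) is expected to be small, hardly beyond the scatter, with a slight lean toward a lower number. For compound 3 an estimate of 4500 nM is made, with a range from 1800 nM to 12000 nM.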

Compound 3, half-maximal effective concentration: 440 nM
Compound 3: the middle estimate sits 10-fold (1.01 log units) above what was measured; the whole stated range lies above it.
By their numbers in this assay, from the lowest: compound 3; then compound 1; then compound 2.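

In this assay, putting 3-(trifluoromethyl)phenyl in place of 4-cyanophenyl on a saturated chain carbon bound to an aromatic carbon gives a 14-fold lower number from compound 1 to compound 3 (1.14 log units; beyond the scatter). The rest of compound 1 stays unchanged, so this single exchange accounts for the whole step, and it shows that the read-out responds strongly to the group at this place, which the earlier compounds could not show. Nothing measured here explains the size of this step.

The two group names differ in both the substituent and its number on the ring, and the compounds shown do not separate these two changes. They also leave open how the number would move with a plain phenyl at this place, or with an amine or a carboxylic acid in place of the nitrile.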